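From 4-chlorobenzyl to 3-bromo-4-methoxybenzyl: a modest gain expected

This account rests on a few compounds, and the source may have more. Where it says the series, first, only, none or still open, it means among the compounds named here.

In a functional assay on MGC-803 cells (Homo sapiens) for inhibition, read by CCK-8 assay, with a stated time of 48 h (a lower number here means a stronger inhibitor, a higher number a weaker inhibitor), compound 1 (`COc1ccc(CN(C(=O)CSC(=S)N2CCOCC2)c2cc(OC)c(OC)c(OC)c2)cc1`) gives 2370 nM and compound 2 (`COc1cc(N(Cc2ccc(Cl)cc2)C(=O)CSC(=S)N2CCN(C(=O)OC(C)(C)C)CC2)cc(OC)c1OC`) gives 12900 nM as the higher of the two numbers, which makes it the weaker inhibitor by a gap beyond the scatter. These two compounds differ in more than one place, so the gap cannot be assigned to a single group. Compound 3 (`COc1ccc(CN(C(=O)CSC(=S)N2CCN(C(=O)OC(C)(C)C)CC2)c2cc(OC)c(OC)c(OC)c2)cc1Br`) keeps the rest of compound 2 and carries 3-bromo-4-methoxyphenyl in place of 4-chlorophenyl (3-bromo-4-methoxyphenyl in place of 4-chlorophenyl on a saturated chain carbon bound to an amide-type nitrogen) on a saturated chain carbon bound to an amide-type nitrogen. Among the measured compounds shown here, no measured pair isolates this change. For the measured compounds named here, the only hint is that compound 1 at 2370 nM also has a methoxy group on its benzyl group. In this assay the expected step of a 1.8-fold lower number from compound 2 to compound 3 (0.27 log units; within the scatter) is therefore small, towards a lower number and probably within the scatter. The estimate for compound 3 is 7000 nM and the expected range runs from 2200 nM up to 20000 nM for this measurement.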

Compound 3, half-maximal inhibitory concentration: 3710 nM
Compound 3: the middle estimate sits 1.9-fold (0.28 log units) above what was measured, within the range that was stated.
By their numbers in this assay, from the lowest: compounds 1 and 3 (each within the scatter of the next); then compound 2.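

Among the compounds shown here, this is the first single-place read at this position: with everything else in compound 2 kept, 3-bromo-4-methoxyphenyl in place of 4-chlorophenyl on a saturated chain carbon bound to an amide-type nitrogen gives a 3.5-fold lower number from compound 2 to compound 3 (0.54 log units; beyond the scatter) in this assay. The aryl group at this place therefore affects the read-out by more than the usual scatter, and the change tolerates a larger substituted ring, which the earlier pair, differing in more than one place, could not show. No measurement here explains the step.

The change adds both bromo and methoxy groups and removes chloro, so the compounds shown do not separate their contributions. On these data alone, how a 3-bromophenyl group or a 4-aminophenyl group would read at this place remains open.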